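The compounds below may be only part of what the source reports. "The series", "measured", "known", "first", "only" and "open" are said of these compounds alone.

In an ADME assay on GES1 cells (Homo sapiens) for cytotoxicity, read by MTT assay, with a stated time of 24 h (on this read-out lower numbers stand for higher toxicity in this test and higher numbers for lower toxicity in this test), compound 1 `O=c1[nH]cc(S(=O)(=O)Nc2cccc(-c3cn(-c4ccccc4)nn3)c2)c(=O)[nH]1` gives 22500 nM, compound 2 `Cc1ccccc1-n1cc(-c2cccc(NS(=O)(=O)c3c[nH]c(=O)[nH]c3=O)c2)nn1` gives 21500 nM, and compound 3 `Cc1ccc(-n2cc(-c3cccc(NS(=O)(=O)c4c[nH]c(=O)[nH]c4=O)c3)nn2)cc1` gives 15800 nM. Compound 3 stands alongside the other two rather than apart from them: the step of a 1.4-fold lower number from compound 1 to compound 3 (0.15 log units; within the scatter) and the step of a 1.4-fold lower number from compound 2 to compound 3 (0.13 log units; within the scatter) both fall within the scatter, as does the step of a 1.0-fold lower number from compound 1 to compound 2 (0.02 log units; within the scatter). The three compounds thus behave alike on this read-out, whatever the substituent on the ring attached to the aromatic nitrogen.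

Compound 4 `O=c1[nH]cc(S(=O)(=O)Nc2cccc(-c3cn(-c4cccc(F)c4)nn3)c2)c(=O)[nH]1` continues this series with 3-fluorophenyl in place of 4-methylphenyl on an aromatic nitrogen. Among the compounds with values here, the steps that bear on this change are those that alter the same ring: the step of a 1.4-fold lower number from compound 2 to compound 3 (0.13 log units; within the scatter) exchanges one methyl-bearing ring for another, and the steps of a 1.0-fold lower number from compound 1 to compound 2 (0.02 log units; within the scatter) and a 1.4-fold lower number from compound 1 to compound 3 (0.15 log units; within the scatter) add a methyl to the ring. None of them moves the number beyond the scatter. The change to a 3-fluorophenyl is of the same kind, a different substituent on the same ring, so no step beyond the scatter is expected in this assay for compound 4. On that basis the estimated step is a 1.1-fold higher number from compound 3 to compound 4 (0.06 log units; within the scatter), and compound 4 is expected to give about 18000 nM in this assay, with a range from 8000 nM to 45000 nM.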

Compound 4, half-maximal cytotoxic concentration: "not toxic" (no number reported)
Nothing numeric was reported for compound 4; there is nothing to compare the estimate with.
By their numbers in this assay, from the lowest: compounds 3, 2 and 1 (each within the scatter of the next).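

Within the data shown here, compound 4 is reported as "not toxic" in this assay without a number, so no step from compound 1, compound 2 or compound 3 to compound 4 can be read. Nothing shown here explains this result. The compounds shown leave open how 3-fluorophenyl compares numerically with 4-methylphenyl on this read-out.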